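Series notes: biaryl amide hexanoic acid ethyl esters, cytotoxicity

The source may hold more compounds than are shown below. What is called first, only, known or untested is meant among the compounds shown, and "the series" means these compounds.

Compound 1 `CC(C)N(Cc1cccc(OCCCCCC(=O)O)c1)C(=O)c1ccc(-c2cccc3ccccc23)cc1` has been run in an ADME assay on HEK293 cells (Homo sapiens) for cytotoxicity, read by CellTiter-Glo and resazurin assay, with a stated time of 72 h; a higher number here means that more compound is needed for the effect, a lower number that less compound is needed. Its reading for compound 1 is a limit, > 26000 nM. Compound 2 `CC(C)N(Cc1cccc(OCCCCCC(=O)O)c1)C(=O)c1ccc(-c2ccc3[nH]ccc3c2)cc1` is also given as a limit, > 26000 nM, in this assay. Compound 3 `CCOC(=O)CCCCCOc1cccc(CN(C(=O)c2ccc(-c3cccc4ccccc34)cc2)C(C)C)c1` is the ethyl ester of compound 1. Compound 3 likewise comes back as a limit, > 26000 nM. The two measured steps, a step that the two limits leave unreadable from compound 1 to compound 2 and a step that the two limits leave unreadable from compound 1 to compound 3, are therefore of unknown size, and compound 3 stands on a limit like every other compound shown; all three values sit at the limit of > 26000 nM in this assay, at which 3 of the 3 values shown sit.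

Compound 4 `CCOC(=O)CCCCCOc1cccc(CN(C(=O)c2ccc(-c3cc(OC)ccc3F)cc2)C(C)C)c1` is the next ester to be measured. It differs from compound 3 by 2-fluoro-5-methoxyphenyl in place of naphthalen-1-yl on an aromatic carbon. The closest measured precedent is the aryl change from compound 1 to compound 2, which was not readable, so no step beyond the scatter is expected in this assay from compound 3 to compound 4, estimated as a step that the limit leaves unreadable from compound 3 to compound 4. Compound 4 is expected to give about 40000 nM, with a range of 15000 nM to 100000 nM, most likely again reported as a limit.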

Compound 4, half-maximal effective concentration: > 26000 nM
Compound 4 ended at the assay's limit (the forecaster's own chance of this, stated with the estimate: 85%); the middle value lies beyond the limit too.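

No step can be read from compound 3 to compound 4 in this assay, since both readings are limits: the limit of > 26000 nM in this assay, at which 4 of the 4 values shown sit.

The compounds shown leave open at what concentration any of them reaches the half-maximal effect in this assay, and whether the aryl changes or the ester change alter it at all.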